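This account rests on a few compounds, and the source may have more. Where it says the series, first, only, none or still open, it means among the compounds named here.

In a functional assay on Bel7402/5-FU cells (Homo sapiens) for antiproliferative activity, read by MTT assay, with a stated time of 72 h (a lower number here means a stronger inhibitor, a higher number a weaker inhibitor), compound 1 `C=C1C(=O)O[C@H]2[C@H]1CC/C(COC(=O)Cn1cc(F)c(=O)[nH]c1=O)=C\CC[C@@]1(C)O[C@@H]21` gives > 20000 nM, which is a limit of the assay and not a number. With a benzyl on an aromatic nitrogen, compound 2 `C=C1C(=O)O[C@H]2[C@H]1CC/C(COC(=O)Cn1cc(F)c(=O)n(Cc3ccccc3)c1=O)=C\CC[C@@]1(C)O[C@@H]21` gives 4270 nM, and with a 4-chlorobenzyl there, compound 3 `C=C1C(=O)O[C@H]2[C@H]1CC/C(COC(=O)Cn1cc(F)c(=O)n(Cc3ccc(Cl)cc3)c1=O)=C\CC[C@@]1(C)O[C@@H]21` gives 2420 nM. These are an at least 4.6-fold lower number from compound 1 to compound 2 (0.67 log units; beyond the scatter) and an at least 8.2-fold lower number from compound 1 to compound 3 (0.91 log units; beyond the scatter). For the measured compounds named here, compound 3 therefore stands within the scatter of compound 2, the only other exact number. Compound 4 `C=C1C(=O)O[C@H]2[C@H]1CC/C(COC(=O)Cn1cc(F)c(=O)n(Cc3ccc(C(F)(F)F)cc3)c1=O)=C\CC[C@@]1(C)O[C@@H]21` carries trifluoromethyl in place of chloro on an aromatic carbon, para to a large group: trifluoromethyl in place of chloro on an aromatic carbon. The closest measured change on that ring is a 1.8-fold lower number from compound 2 to compound 3 (0.25 log units; within the scatter). No step beyond the scatter is therefore expected in this assay. The expected result is a 1.0-fold higher number from compound 3 to compound 4 (0.01 log units; within the scatter). Compound 4 is estimated at 2500 nM, with an expected range of 1000 nM to 6500 nM.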

Compound 4, half-maximal inhibitory concentration: 2250 nM
Beside the measured number, compound 4's estimate is 1.1-fold (0.05 log units) above it, within the range that was stated.
By their numbers in this assay, from the lowest: compounds 4, 3 and 2 (each within the scatter of the next). At a limit, above all of these: compound 1.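

In this assay, trifluoromethyl, with 4 heavy atoms against 1 for chloro, takes this place on the ring with no change beyond the scatter (a 1.1-fold lower number from compound 3 to compound 4 (0.03 log units; within the scatter)), and the same holds against the plain benzyl (a 1.9-fold lower number from compound 2 to compound 4 (0.28 log units; within the scatter)). For the compounds shown here, the one step beyond the scatter remains that from the free nitrogen (an at least 8.8-fold lower number from compound 1 to compound 4 (0.94 log units; beyond the scatter)), and its size is only a bound. Compound 1 stands at a limit: the limit of > 20000 nM in this assay, at which 1 of the 4 values shown sits. From the compounds shown here alone, whether an amine or a carboxylic acid at this place would move the number stays open, as does a longer chain in place of the benzyl.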